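Working notes: trifluoromethyl in place of cyano

The source may hold more compounds than are shown below. What is called first, only, known or untested is meant among the compounds shown, and "the series" means these compounds.

Compound 1 `Cc1cc(CCC(=O)O)ccc1-c1noc(-c2ccc(OC(C)C)c(C#N)c2)n1` is the reference point of this set. In an assay on CHO cells for displacement of a labelled ligand from sphingosine 1-phosphate receptor 4 (Homo sapiens) (on this read-out lower numbers stand for stronger inhibition and higher numbers for weaker inhibition), compound 1 gives > 10000 nM, which is a limit of the assay and not a number. Compound 2 `Cc1cc([C@H]2C[C@H]2C(=O)O)ccc1-c1noc(-c2ccc(OC(C)C)c(C#N)c2)n1` carries 2-carboxycyclopropyl in place of 2-carboxyethyl on an aromatic carbon, and in this assay compound 2 gives > 10000 nM, again a limit. The step that the two limits leave unreadable from compound 1 to compound 2 is therefore unreadable. Compound 3 `Cc1nc(CCC(=O)O)ccc1-c1noc(-c2ccc(OC(C)C)c(C#N)c2)n1` likewise stops at a limit, giving > 10000 nM in this assay. Within the data shown here, the evidence the limit of > 10000 nM in this assay, at which 3 of the 3 values shown sit, thus puts every measured value at the same limit, so compound 1 stands nowhere above or below its neighbours that can be told apart, and no measured step has a readable size.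

Compound 4 `Cc1cc(CCC(=O)O)ccc1-c1noc(-c2ccc(OC(C)C)c(C(F)(F)F)c2)n1` is the one not yet measured. It differs from compound 1 by trifluoromethyl in place of cyano on an aromatic carbon. Among the measured compounds shown here, no measured step bears on this change: the only step between measured compounds, a step that the two limits leave unreadable from compound 1 to compound 2, concerns a different group and is unreadable in any case. Given that compound 1 sits at the limit, the expected step that the limit leaves unreadable from compound 1 to compound 4 in this assay has no readable direction, and the expectation is that compound 4 stays at or near the limit. The estimate for compound 4 in this assay is 20000 nM, ranging from 5000 nM to 100000 nM, most likely returned as a limit once more.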

Compound 4, half-maximal inhibitory concentration: > 10000 nM
Compound 4 was reported as a limit; the forecaster's own chance of this, stated with the estimate: 80%; the middle value does not contradict the limit.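

Compound 1 and compound 4 both end at a limit, so no step between them can be read in this assay and trifluoromethyl in place of cyano has no measurable size here: the limit of > 10000 nM in this assay, at which 4 of the 4 values shown sit.

The compounds shown leave open which change to the shared core, if any, would bring a value inside the readable range of this assay and so allow a comparison.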